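Replacing the Indanyl Group on a Sulfonamide Nitrogen

This account rests on a few compounds, and the source may have more. Where it says the series, first, only, none or still open, it means among the compounds named here.

In a physicochemical assay for lipophilicity, at pH 7.4 (on this read-out lower numbers stand for lower lipophilicity and higher numbers for higher lipophilicity), compound 1 `CC(C)CN(C1CCc2ccc(F)cc21)S(=O)(=O)c1ccc2c(c1)C(=O)CC(C1CCOCC1)O2` gives 4.03 as its reading. That lies within the scatter of compound 2 `CCc1ccc(N(CC2CC2)S(=O)(=O)c2ccc3c(c2)C(=O)CC(C2CCOCC2)O3)cc1` at 3.77 on the same scale, while compound 3 `CCc1ccc(N(Cc2ccccc2)S(=O)(=O)c2ccc3c(c2)C(=O)CC(C2CCOCC2)O3)cc1` stands clearly higher at 4.84 in this small set. Still unmeasured is compound 4 `Cc1ccc(N(CC(C)C)S(=O)(=O)c2ccc3c(c2)C(=O)CC(C2CCOCC2)O3)c(C)c1` and its difference from the first compound is 2,4-dimethylphenyl in place of 6-fluoro-2,3-dihydro-1H-inden-1-yl on a sulfonamide nitrogen with the saturated chain on that nitrogen and the shared core untouched. Within the data shown here, only one measured step exists, and it bears on this change only indirectly. The step of a number 1.07 log units higher from compound 2 to compound 3 (beyond the scatter) is large, but it alters the chain on the nitrogen, which stays the same here. Compound 2 offers closer guidance, as it also has an aromatic ring directly on the sulfonamide nitrogen. Compound 2 gives 3.77 and this sits within the scatter of compound 1 at 4.03 so no large shift is expected. The expected step is a number 0.07 log units higher from compound 1 to compound 4 (within the scatter) and it is estimated to stay within the scatter. For compound 4 the expected value in this assay is 4.1 with an estimated range from 3.7 to 4.5 as its likely span.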

Compound 4, distribution coefficient: 4.28
Beside the measured number, compound 4's estimate is 0.18 log units below it; the range from low to high includes it.
By their numbers in this assay, from the lowest: compounds 2, 1 and 4 (each within the scatter of the next, the first and the last beyond it); then compound 3.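

In this assay, putting 2,4-dimethylphenyl in place of 6-fluoro-2,3-dihydro-1H-inden-1-yl on a sulfonamide nitrogen gives a number 0.25 log units higher from compound 1 to compound 4 (within the scatter), with the saturated chain on that nitrogen left as it was. Among these compounds, the one earlier step concerned the chain on the nitrogen, so this is the first direct reading of a change to the other carbon group there: for this pair, the five-membered non-aromatic ring and the fluorine can go without the number leaving the scatter. Nothing in the data accounts for this result.

The compounds shown leave open how a pyridine ring or a carboxylic acid at this place on the sulfonamide nitrogen would read. They also leave open whether the same exchange would give a similar step with a different chain on that nitrogen.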